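This account rests on a few compounds, and the source may have more. Where it says the series, first, only, none or still open, it means among the compounds named here.

The measured compounds:

Compound 1, `CC(=O)Nc1ccc(OC(=S)Nc2ccc(Nc3ccc(C(Cl)(Cl)Cl)cc3)cc2)cc1`: in a physicochemical assay for lipophilicity (a lower number here means a more polar compound, a higher number a more lipophilic compound), compound 1 gives 6.07.
Compound 2, `CC(=O)Nc1ccc(OC(=S)Nc2ccc(Oc3ccc([N+](=O)[O-])cc3)cc2)cc1`: in this assay compound 2 gives 4.81.
Compound 3, `CC(=O)Nc1ccc(OC(=S)Nc2ccc(Oc3ccc(C(F)(F)F)cc3)cc2)cc1`: in this assay compound 3 gives 5.41.

Compound 2 stands lowest of the three numbers. Going by the values given here, its nearest neighbour is compound 3, and that one measured step, a number 0.60 log units higher from compound 2 to compound 3 (beyond the scatter), is the only step in this set. Among the compounds with values here, compound 1 differs from compound 2 in two places, so no single step is drawn between them; its value simply lies furthest from compound 2, beyond the scatter.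

The next compound, compound 4, is `CC(=O)Nc1ccc(OC(=S)Nc2ccc(Sc3ccc([N+](=O)[O-])cc3)cc2)cc1`. Its difference from compound 2 is (4-nitrophenyl)sulfanyl in place of 4-nitrophenoxy on an aromatic carbon. Within the data shown here, no measured step swaps these two groups, so nothing in the set speaks directly to the change; the step from compound 2 to compound 3 shows only how much the number moved when another group on that same ring was exchanged, and it was modest. On the structural change alone, compound 4 is expected to come out higher than compound 2 in this assay, by a number 0.59 log units higher from compound 2 to compound 4 (beyond the scatter), a step of roughly the size seen in a number 0.60 log units higher from compound 2 to compound 3 (beyond the scatter). Compound 4 is therefore estimated at 5.4, with a range from 5 to 5.8.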

Compound 4, partition coefficient: 5.06
For compound 4 the middle estimate is 0.34 log units above the measured one; the range from low to high includes it.
By their numbers in this assay, from the lowest: compounds 2 and 4 (each within the scatter of the next); then compound 3; then compound 1.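

In this assay, the exchange of 4-nitrophenoxy for (4-nitrophenyl)sulfanyl on an aromatic carbon, para to a large group, gives a number 0.25 log units higher from compound 2 to compound 4 (within the scatter) and so does not separate the two compounds on this read-out. Going by these compounds alone, the earlier set offered only a change in which the nitro group itself was replaced, a number 0.60 log units higher from compound 2 to compound 3 (beyond the scatter) being printed as beyond the scatter, whereas this is the first step in which the nitro group stays and the oxygen of the 4-nitrophenoxy group gives way to sulfur. Nothing available bears on why the number responds in this way at this position.

The compounds shown leave open whether the same exchange of oxygen for sulfur would read alike with trifluoromethyl in place of nitro, and whether a methylene or sulfonyl group in that spot would also stay within the scatter of compound 2. Compound 1 differs from compound 2 in two places, so the part played by its amine link cannot be read apart from that of its trichloromethyl group.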